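Methylating the Sulfonamide Nitrogen of a Bromophenyl Sulfonamide

The source may report more compounds than this note shows. Statements on the series, on what has been measured and on what is new or still open speak of the compounds shown alone.

Three compounds share a core in which a sulfonamide links a halogen-bearing benzene ring to a two-carbon chain ending in a seven-membered saturated amine ring. Compound 1 is `O=S(=O)(NCCN1CCCCCC1)c1ccc(I)cc1`, compound 2 is `COc1ccc(S(=O)(=O)N(C)CCN2CCCCCC2)cc1I` and compound 3 is `O=S(=O)(NCCN1CCCCCC1)c1ccc(Br)cc1`. In an assay on membranes from brain (Cavia porcellus) for binding affinity to Sigma non-opioid intracellular receptor 1 (Homo sapiens) (on this read-out higher numbers stand for weaker inhibition and lower numbers for stronger inhibition), compound 1 gives 1.32 nM, compound 2 gives 3.11 nM and compound 3 gives 0.63 nM. Among the measured compounds shown here, compound 3 therefore holds the lowest number of the three; its closest neighbour is compound 1, and the single change between them, a 2.1-fold lower number from compound 1 to compound 3 (0.32 log units; beyond the scatter), is a modest step beyond the scatter.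

Compound 4 is `CN(CCN1CCCCCC1)S(=O)(=O)c1ccc(Br)cc1`. It differs from compound 3 in one place: methyl in place of hydrogen on a sulfonamide nitrogen. For the measured compounds named here, no measured pair isolates this change. Compound 2 also carries a methyl on its sulfonamide nitrogen, but it differs from compound 3 in other places too, so its higher number cannot be attributed to the methyl alone. With nothing to suggest a large shift, compound 4 is expected to stay close to compound 3 in this assay, and the estimated change a 1.9-fold higher number from compound 3 to compound 4 (0.28 log units; within the scatter) is small. The expected value for compound 4 is 1.2 nM, within a range from 0.4 nM to 3.5 nM.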

Compound 4, inhibition constant: 0.18 nM
Compound 4: middle estimate off by 6.7-fold (0.82 log units), on the high side; measured number outside the range, below it.
By their numbers in this assay, from the lowest: compound 4; then compound 3; then compound 1; then compound 2.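

In this assay the exchange of hydrogen for methyl on a sulfonamide nitrogen gives a 3.5-fold lower number from compound 3 to compound 4 (0.54 log units; beyond the scatter) and this is the first pair among these compounds that isolates the change. It shows that, at least with bromo on the benzene ring, this nitrogen does not have to keep its hydrogen for the number to stay low: the single added carbon moves the value towards stronger inhibition, by a step beyond the usual scatter, and compound 4 now holds the lowest number of the four. Nothing available here explains why this methyl lowers the number.

As far as these compounds go, this is one pair, so it remains open whether the same methyl would lower the number of the iodo compound, compound 1, as well. From the compounds shown here alone, it is also open whether the trend continues with an ethyl or a longer chain on the same nitrogen, or whether a group as small as this methyl is the limit of what this position accepts in this read-out.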